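Three Limits and an Expected Fourth

The source may report more compounds than this note shows. Statements on the series, on what has been measured and on what is new or still open speak of the compounds shown alone.

Compound 1 `Cc1ncnc2c1c(-c1cccs1)cn2[C@@H]1O[C@H](CO)[C@@H](O)[C@H]1O`: in a functional assay on K562 cells (Homo sapiens), read by MTT assay, with a stated time of 72 h (a lower number here means a stronger inhibitor, a higher number a weaker inhibitor), compound 1 gives > 20000 nM, a limit of the assay.
Compound 2 `CNc1ncnc2c1c(-c1cccs1)cn2[C@@H]1O[C@H](CO)[C@@H](O)[C@H]1O`: in this assay compound 2 gives > 20000 nM, a limit of the assay.
Compound 3 `CNc1ncnc2c1c(-c1ccsc1)cn2[C@@H]1O[C@H](CO)[C@@H](O)[C@H]1O`: in this assay compound 3 gives > 20000 nM, a limit of the assay.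

Compound 4 `Cc1ncnc2c1c(-c1ccsc1)cn2[C@@H]1O[C@H](CO)[C@@H](O)[C@H]1O` has not yet been measured in this assay. It differs from compound 3 by methyl in place of methylamino on an aromatic carbon. The same change, (methyl in place of methylamino on an aromatic carbon), connects two measured compounds, and there the step that the two limits leave unreadable from compound 2 to compound 1 because both values sit at the limit of > 20000 nM in this assay, at which 3 of the 3 values shown sit. The cores of compound 2 and compound 3 differ by thiophen-3-yl in place of thiophen-2-yl on an aromatic carbon, and that step, a step that the two limits leave unreadable from compound 2 to compound 3, is equally unreadable. The place of the change is worded identically in both cases, so it is the same change. For compound 4 the step that the limit leaves unreadable from compound 3 to compound 4 is expected to leave it at the limit too, resting on (the limit of > 20000 nM in this assay, at which 3 of the 3 values shown sit), where every measured compound sits. Compound 4 is estimated at 30000 nM, within a range from 15000 nM to 100000 nM.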

Compound 4, half-maximal inhibitory concentration: 5550 nM
Compound 4: the middle estimate sits 5.4-fold (0.73 log units) above what was measured; the whole stated range lies above it.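

In this assay, methyl in place of methylamino on the core carrying thiophen-3-yl gives an at least 3.6-fold lower number from compound 3 to compound 4 (0.55 log units; beyond the scatter), and thiophen-3-yl in place of thiophen-2-yl among the methyl compounds gives an at least 3.6-fold lower number from compound 1 to compound 4 (0.55 log units; beyond the scatter). The matching steps on the other side of this set cannot be read, because each joins two compounds at the limit: the limit of > 20000 nM in this assay, at which 3 of the 4 values shown sit. Only compound 4 has a measured number, so the gain is shown on one core alone, and neither its true size nor whether it carries over to the core with thiophen-2-yl is shown.

Still open, on these data alone, is how a plain amine or an ethyl group would behave in place of the methyl of compound 4. As far as these compounds go, a phenyl ring in place of the thiophen-3-yl is equally open.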